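A few compounds are considered here, and "the series" means these few. Any claim that something is new, unique, unknown or untested is made for them only; others in the source may bear on it.

Three compounds share one core and differ only at the far end of the molecule. Compound 1 `Nc1ccc(-c2ccc(NC3=CC(=O)c4ncncc4C3=O)cc2)cc1` carries an amino group there, compound 2 `CCc1ccc(-c2ccc(NC3=CC(=O)c4ncncc4C3=O)cc2)cc1` an ethyl group, and compound 3 `O=C1C(Nc2ccc(-c3ccc(F)cc3)cc2)=CC(=O)c2ncncc21` a fluoro group. In a functional assay on MIA PaCa-2 cells (Homo sapiens) for cytotoxicity, read by MTT assay, with a stated time of 72 h (on this read-out lower numbers stand for stronger inhibition and higher numbers for weaker inhibition), compound 1 gives 2500 nM, compound 2 gives 2000 nM, and compound 3 gives 3500 nM. Compound 3 has the highest of the three numbers, but the gaps are small: a 1.4-fold higher number from compound 1 to compound 3 (0.15 log units; within the scatter) and a 1.8-fold higher number from compound 2 to compound 3 (0.24 log units; within the scatter), and likewise a 1.3-fold lower number from compound 1 to compound 2 (0.10 log units; within the scatter). None of these swaps moved the number beyond the scatter.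

Compound 4 `CCOC(=O)c1ccc(NC2=CC(=O)c3ncncc3C2=O)cc1` is a different kind of change: ethoxycarbonyl in place of 4-fluorophenyl on an aromatic carbon. Among the compounds with values here, no measured step removes a whole ring in this way, so the three small steps bear on it only loosely, showing that the end of the molecule tolerated small exchanges. Within the data shown here, with a larger change and no direct precedent, a modest rise in the number is expected, namely a 1.4-fold higher number from compound 3 to compound 4 (0.15 log units; within the scatter). Compound 4 is therefore estimated at 5000 nM, within a range from 1500 nM to 16000 nM.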

Compound 4, half-maximal inhibitory concentration: 5500 nM
Estimate against measurement, compound 4: 1.1-fold (0.04 log units) below; the range from low to high includes it.
By their numbers in this assay, from the lowest: compounds 2, 1, 3 and 4 (each within the scatter of the next, the first and the last beyond it).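

Compound 4 shows that this position tolerates more than small exchanges: with the whole 4-fluorophenyl group, ring included, replaced by ethoxycarbonyl, the step is a 1.6-fold higher number from compound 3 to compound 4 (0.20 log units; within the scatter). Against the other two compounds, the same kind of exchange gives the first differences in this set that clear the scatter, a 2.8-fold higher number from compound 2 to compound 4 (0.44 log units; beyond the scatter) and a 2.2-fold higher number from compound 1 to compound 4 (0.34 log units; beyond the scatter), though both are modest. No measured evidence accompanies these numbers to explain them.

Compound 4 loses a ring and gains an ester in a single exchange, so the compounds shown cannot separate the effect of one from the other. A carboxylic acid or an amide at this position, or a longer chain on the ester, would help to tell these apart.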